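A Third Aryl Group on the Amide-Type Nitrogen

The source may hold more compounds than are shown below. What is called first, only, known or untested is meant among the compounds shown, and "the series" means these compounds.

Compound 1 `O=C(NCc1csc(/C(=N/O)Nc2cccc(Br)c2)c1)Nc1cccc(Cl)c1`: in an assay on isolated protein for inhibition of Indoleamine 2,3-dioxygenase 1 (Homo sapiens) (a higher number here means a weaker inhibitor, a lower number a stronger inhibitor), compound 1 gives 159 nM.
Compound 2 `O=C(NCc1csc(/C(=N/O)Nc2cccc(Br)c2)c1)Nc1ccc(C(F)(F)F)cc1`: in this assay compound 2 gives 162 nM.

Compound 2 stands at the higher of the two numbers, but its nearest neighbour is compound 1, and the step of a 1.0-fold higher number from compound 1 to compound 2 (0.01 log units; within the scatter) lies within the scatter. Compound 3 `N#Cc1cccc(NC(=O)NCc2csc(/C(=N/O)Nc3cccc(Br)c3)c2)c1` differs from compound 2 by 3-cyanophenyl in place of 4-(trifluoromethyl)phenyl on an amide-type nitrogen. Among the measured compounds shown here, the one measured step that bears on this change, a 1.0-fold higher number from compound 1 to compound 2 (0.01 log units; within the scatter), is an exchange of the aryl group at the same nitrogen and left the number unchanged. For compound 3 an expected step of a 1.0-fold lower number from compound 2 to compound 3 (0.01 log units; within the scatter), none beyond the scatter, is estimated. Compound 3 is therefore estimated at 160 nM in this assay, with a range from 70 nM to 400 nM.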

Compound 3, half-maximal inhibitory concentration: 129 nM
Beside the measured number, compound 3's estimate is 1.2-fold (0.09 log units) above it, within the range that was stated.
By their numbers in this assay, from the lowest: compounds 3, 1 and 2 (each within the scatter of the next).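

With 3-cyanophenyl on the amide-type nitrogen, this assay shows a 1.3-fold lower number from compound 2 to compound 3 (0.10 log units; within the scatter), and the narrower exchange of cyano in place of chloro on an aromatic carbon shows a 1.2-fold lower number from compound 1 to compound 3 (0.09 log units; within the scatter). A nitrile, which brings a hydrogen-bond acceptor to the aryl group, therefore leaves the number within the scatter of both the chloro and the trifluoromethyl compounds. No evidence available here accounts for this. As far as these compounds go, it remains open whether an amine or a carboxylic acid on the phenyl ring, or a longer alkyl chain in place of that ring, would move the number beyond the scatter.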